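A few compounds are considered here, and "the series" means these few. Any claim that something is new, unique, unknown or untested is made for them only; others in the source may bear on it.

Measured compounds:
compound 1, `COc1ccccc1OCCNc1ccc(=O)n(Cc2ccc(OC)c(OC3CCCC3)c2)n1`, 28000 nM in a functional assay on K562 cells (Homo sapiens) for antiproliferative activity, read by MTT assay, with a stated time of 48 h; a lower number here means a stronger inhibitor of growth, a higher number a weaker inhibitor of growth
compound 2, `COc1ccccc1OCCNc1cnn(Cc2ccc(OC(F)F)c(OC3CCCC3)c2)c(=O)c1Cl`, > 100000 nM in this assay

Among the measured compounds shown here, compound 1 is the only measured compound for which this assay returns a number; in this assay compound 1 gives 28000 nM. For compound 2 this assay reports only a limit, > 100000 nM, and the limit of > 100000 nM in this assay, at which 1 of the 2 values shown sits, is where that value sits. For the measured compounds named here, the two compounds differ in more than one place, so no single step between them can be read from their values.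

Compound 3, `COc1ccc(Cn2nc(NCCOc3ccccc3OC)ccc2=O)cc1Br`, has not yet been measured in this assay. It differs from compound 1 by bromo in place of cyclopentyloxy on an aromatic carbon. Since compound 1 itself is a weak inhibitor of growth in this assay, the step from compound 1 to compound 3 is expected to be small, with a slight loss of potency as the more likely direction, a 1.6-fold higher number from compound 1 to compound 3 (0.21 log units; within the scatter). The estimate for compound 3 in this assay is 45000 nM, within a range from 12000 nM to 150000 nM.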

Compound 3, concentration for 50% growth inhibition: > 100000 nM
Compound 3: a limit, no number (the forecaster's own chance of this, stated with the estimate: 35%); at least 2.2-fold (0.34 log units) between middle value and limit.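

The replacement of cyclopentyloxy by bromo on this aromatic carbon, ortho to a methoxy group, gives an at least 3.5-fold higher number from compound 1 to compound 3 (0.55 log units; beyond the scatter) in this assay. Among the compounds shown here, this is the first single change that can be read, and it shows that this position is not indifferent: with a group of 6 heavy atoms replaced by a single bromine, the measurable growth inhibition of compound 1 no longer appears. Compound 3 gives only a limit, so the step has a minimum size but no measured size, and compound 3 joins compound 2 at the same limit: the limit of > 100000 nM in this assay, at which 2 of the 3 values shown sit.

Going by these compounds, what remains open is whether the loss follows from the missing five-membered ring or from the missing ether oxygen. An ethoxy or cyclohexyloxy group on this carbon would separate the two, and a hydroxyl group or an amine would extend the comparison to different kinds of substituent.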